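Swapping one aromatic group: what tolerance to expect

The compounds below may be only part of what the source reports. "The series", "measured", "known", "first", "only" and "open" are said of these compounds alone.

compound 1 `Cc1csc(-c2cc(C)c(Nc3ccnc(Nc4ccc(C#N)cc4)n3)c(C)c2)c1`: 34000 nM
compound 2 `Cc1cc(-c2cc(C)c(Nc3ccnc(Nc4ccc(C#N)cc4)n3)c(C)c2)cc(C)n1`: 2300 nM

For the measured compounds named here, in a toxicity assay on MT4 cells (Homo sapiens) for cytotoxicity, read by MTT assay, with a stated time of 5 days (a higher number here means that more compound is tolerated, a lower number that less compound is tolerated), compound 2 gives 2300 nM and holds the lower of the two numbers so far, so less of it is tolerated than of compound 1. Compound 3 `Cc1cc(-c2cnc(C(F)(F)F)nc2)cc(C)c1Nc1ccnc(Nc2ccc(C#N)cc2)n1` differs from compound 2 in one place: 2-(trifluoromethyl)pyrimidin-5-yl in place of 2,6-dimethylpyridin-4-yl on an aromatic carbon and the new group sits on the same aromatic carbon.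

Going by the values given here, one measured step bears on this swap, made at that same place: a 15-fold lower number from compound 1 to compound 2 (1.17 log units; beyond the scatter) with 2,6-dimethylpyridin-4-yl entering in place of 4-methylthiophen-2-yl. Among the compounds with values here, that shows how far a change here can move the number, but no measurement yet covers 2-(trifluoromethyl)pyrimidin-5-yl. Within the data shown here, compound 2 has the lower of only two values, so a moderate rise is expected, smaller than that large step. The expected change is a 3.0-fold higher number from compound 2 to compound 3 (0.48 log units; beyond the scatter) in this assay and its size is uncertain. For compound 3 the estimated value is 7000 nM (range 1800 nM to 30000 nM).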

Compound 3, half-maximal cytotoxic concentration: 4900 nM
The estimate for compound 3 lay 1.4-fold (0.15 log units) above the measured number; the range from low to high includes it.
By their numbers in this assay, from the lowest: compound 2; then compound 3; then compound 1.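

At this aromatic carbon, this assay now has a third group to compare, and the trifluoromethyl-bearing ring gives only a modest rise over the dimethylpyridine (a 2.1-fold higher number from compound 2 to compound 3 (0.33 log units; beyond the scatter)) while staying clearly lower than the methylthiophene (a 6.9-fold lower number from compound 1 to compound 3 (0.84 log units; beyond the scatter)). Both 2,6-dimethylpyridin-4-yl and 2-(trifluoromethyl)pyrimidin-5-yl, six-membered aromatic rings carrying hetero atoms, therefore leave less compound tolerated than 4-methylthiophen-2-yl, and they lie closer to each other than either lies to it. Nothing measured here explains this order.

Going by these compounds, it remains open whether the trifluoromethyl group or the second ring nitrogen accounts for the step from the dimethylpyridine, and a plain pyrimidin-5-yl group would help separate the two. On these data alone, all three groups are aromatic rings, so the effect of an amine or a carboxylic acid at this carbon also stays unknown.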